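The source may hold more compounds than are shown below. What is called first, only, known or untested is meant among the compounds shown, and "the series" means these compounds.

Measured in a functional assay on KB cells (Homo sapiens) for cytotoxicity, read by MTT assay, with a stated time of 3 days; on this read-out lower numbers stand for stronger inhibition and higher numbers for weaker inhibition:
- Compound 1 `N#Cc1c(Cl)nc(SCc2nc3ccccc3[nH]2)nc1-c1ccccc1`: 3.7 nM
- Compound 2 `CNc1nc(SCc2nc3ccccc3[nH]2)nc(-c2ccccc2)c1C#N`: 2.7 nM
- Compound 3 `N#Cc1c(Nc2nccs2)nc(SCc2nc3ccccc3[nH]2)nc1-c1ccccc1`: 14.7 nM

Compound 3 has the highest number of the three. Two steps led to that number, each bringing a thiazole-bearing group into the series: a 4.0-fold higher number from compound 1 to compound 3 (0.60 log units; beyond the scatter), and a 5.4-fold higher number from compound 2 to compound 3 (0.74 log units; beyond the scatter). By contrast, the change between the two smaller substituents gave a 1.4-fold lower number from compound 1 to compound 2 (0.14 log units; within the scatter).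

Compound 4 `N#Cc1c(-c2ccccc2)nc(SCc2nc3ccccc3[nH]2)nc1N1CCNCC1` has piperazin-1-yl in place of (1,3-thiazol-2-yl)amino on an aromatic carbon, ortho to a cyano group: piperazin-1-yl in place of (1,3-thiazol-2-yl)amino on an aromatic carbon. For the measured compounds named here, no measured compound carries piperazin-1-yl, so the evidence is indirect. The two steps to compound 3 are the closest guide, and the thiazole-bearing group leaves in this change. A modest move back towards the numbers of compound 1 and compound 2 is therefore expected, with some uncertainty. The expected change is a 2.5-fold lower number from compound 3 to compound 4 (0.39 log units; beyond the scatter), towards a lower number. The estimate for compound 4 is 6 nM, with an expected range of 2 nM to 20 nM.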

Compound 4, half-maximal inhibitory concentration: 2.87 nM
The estimate for compound 4 lay 2.1-fold (0.32 log units) above the measured number, within the range that was stated.
By their numbers in this assay, from the lowest: compounds 2, 4 and 1 (each within the scatter of the next); then compound 3.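

At the carbon ortho to a cyano group, piperazin-1-yl is accommodated in this assay without a shift beyond the scatter, as shown by a 1.1-fold higher number from compound 2 to compound 4 (0.03 log units; within the scatter) and a 1.3-fold lower number from compound 1 to compound 4 (0.11 log units; within the scatter), so this six-membered non-aromatic ring is level with both methylamino and chloro. Piperazin-1-yl and (1,3-thiazol-2-yl)amino have the same count of heavy atoms, yet the exchange gives a 5.1-fold lower number from compound 3 to compound 4 (0.71 log units; beyond the scatter), so among these four compounds the heavy-atom count of the substituent does not track the number, and only compound 3 stands apart. Nothing available here explains that gap.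

The compounds shown leave open whether the higher number of compound 3 goes with the thiazole ring itself or with any aromatic ring carried on the amine nitrogen, which phenylamino at this carbon would address. They also leave open whether the second ring nitrogen of piperazin-1-yl matters, which morpholin-4-yl would address.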